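Swapping the Amide Substituent on a Dienamide Chain

The compounds below may be only part of what the source reports. "The series", "measured", "known", "first", "only" and "open" are said of these compounds alone.

Measured compounds:
compound 1 `COc1ccc(CNC(=O)/C=C/C=C/[C@H](O)Cc2ccc(OC)c(OC)c2)cc1`, 16800 nM
compound 2 `CCNC(=O)/C=C/C=C/[C@H](O)Cc1ccc(OC)c(OC)c1`, 13800 nM
compound 3 `COc1ccc(C[C@@H](O)/C=C/C=C/C(=O)NCc2cc(OC)c(OC)c(OC)c2)cc1OC`, 19200 nM

All three share a chain carrying a hydroxyl group, two double bonds and an amide, and all were tested in a functional assay on A549 cells (Homo sapiens) for antiproliferative activity, read by sulforhodamine B assay, with a stated time of 48 h; a higher number here means a weaker inhibitor, a lower number a stronger inhibitor. Compound 2 gives the lowest of the three numbers, yet its gaps to compound 1 and compound 3 both lie within the scatter, so no order among them can be read from these values.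

The unmeasured compound 4 `COc1ccc(C[C@@H](O)/C=C/C=C/C(=O)N2CCN(C)CC2)cc1OC` differs from compound 2 at the amide. The change is 4-methylpiperazin-1-yl in place of ethylamino on a carbonyl carbon.

For the measured compounds named here, only one measured step touches the same place: a 1.2-fold lower number from compound 1 to compound 2 (0.09 log units; within the scatter), where a methyl took the place of 4-methoxyphenyl on the chain carbon bound to the amide nitrogen, and the number barely moved. Going by the values given here, that step shows tolerance of changes beside the amide nitrogen, but none of the measured compounds carries a ring on the amide nitrogen itself, nor loses the amide hydrogen, so the data give no direct guide for compound 4.

On that basis compound 4 is expected to stay close to compound 2, with an estimated step of a 1.1-fold higher number from compound 2 to compound 4 (0.04 log units; within the scatter). Compound 4 is therefore estimated at 15000 nM, within a range from 5000 nM to 45000 nM.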

Compound 4, half-maximal inhibitory concentration: 22200 nM
The estimate for compound 4 lay 1.5-fold (0.17 log units) below the measured number, and the stated range covers the measured number.
By their numbers in this assay, from the lowest: compounds 2, 1, 3 and 4 (each within the scatter of the next).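

In this assay, putting 4-methylpiperazin-1-yl in place of ethylamino on the carbonyl carbon gives a 1.6-fold higher number from compound 2 to compound 4 (0.21 log units; within the scatter) and so produces no readable shift. This is the first compound shown to lack the amide hydrogen and to carry a six-membered non-aromatic ring in the group on the carbonyl carbon, as the earlier compounds all keep that hydrogen and have no such ring there. At this position, then, the amide hydrogen can be absent and the ring present without a step beyond the scatter, a tolerance that the earlier step, made on the chain carbon bound to the amide nitrogen, could not reveal. Nothing shown here gives a cause for this outcome.

The compounds shown leave open which part of 4-methylpiperazin-1-yl matters, since a piperidin-1-yl or morpholin-4-yl group on the same carbonyl carbon would separate the effect of the ring from that of its second nitrogen. They also leave open whether a simple dimethylamino group or a carboxylic acid at this place would give a step beyond the scatter.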